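Thallium flux series: linker change from compound 2 to compound 3

This account rests on a few compounds, and the source may have more. Where it says the series, first, only, none or still open, it means among the compounds named here.

Measured so far:
compound 1 `COc1ccc(C(=O)O)cc1OCCCCOc1ccc(C(=O)CC(C)C)c(O)c1C` — 100%
compound 2 `Cc1c(OCCCCOCOc2ccc(C(=O)O)cc2)ccc(C(=O)CC2CCCC2)c1O` — 46.9%

In an assay on HEK293 cells for positive allosteric modulation of metabotropic glutamate receptor 3 (Rattus norvegicus), read by thallium flux, with a stated time of 2.5 min (on this read-out lower numbers stand for smaller maximal responses and higher numbers for larger maximal responses), compound 2 gives 46.9%, the lower of the two numbers shown; compound 1 gives 100%, a gap beyond the usual scatter. Compound 3 `Cc1cc(C(=O)O)ccc1OCCCCOc1ccc(C(=O)CC2CCCC2)c(O)c1C` is not yet measured. It differs from compound 2 by 4-carboxy-2-methylphenyl in place of (4-carboxyphenoxy)methyl on an oxygen on a saturated carbon. Among the compounds with values here, no measured pair follows this change, so the step is uncertain; a rise in this assay toward the response of compound 1 is expected, because compound 1 gives 100% with a related linker. The estimated step is a number 23.1 percentage points higher from compound 2 to compound 3 (beyond the scatter). For compound 3 the estimate is 70%, range 40% to 100%.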

Compound 3, largest response reached (reported as percent of maximum), in percent of the reference or control that the assay uses: 28.4%
Compound 3: the middle estimate sits 41.6 percentage points above what was measured; measured number outside the range, below it.
By their numbers in this assay, from the lowest: compound 3; then compound 2; then compound 1.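

In this assay, 4-carboxy-2-methylphenyl in place of (4-carboxyphenoxy)methyl on the oxygen is a number 18.5 percentage points lower from compound 2 to compound 3 (beyond the scatter), so this position does respond to the group it carries. The change does not raise the maximal response here. No available data bear on why the response falls.

Within the data shown here, the single step swaps the whole group, so the ring methyl and the lost (4-carboxyphenoxy)methyl linkage cannot be separated. Going by these compounds, how a tetrazole in place of the carboxylic acid would read out also remains open.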